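Swapping the oxygen-linked group on compound 2

A few compounds are considered here, and "the series" means these few. Any claim that something is new, unique, unknown or untested is made for them only; others in the source may bear on it.

Values in a functional assay on RS4-11 cells (Homo sapiens) for inhibition, read by CCK-8 assay, with a stated time of 72 h; a lower number here means a stronger inhibitor, a higher number a weaker inhibitor:
- Compound 1 `CN1CCC(CNc2ccc(S(=O)(=O)NC(=O)c3ccc(N4CCN(CC5=C(c6ccc(C(F)(F)F)cc6)CC(C)(C)CC5)CC4)cc3Oc3cnc4[nH]ccc4c3)cc2[N+](=O)[O-])C1`: 8.3 nM
- Compound 2 `CC(Oc1ccc(S(=O)(=O)NC(=O)c2ccc(N3CCN(CC4=C(c5ccc(C(F)(F)F)cc5)CC(C)(C)CC4)CC3)cc2Oc2cnc3[nH]ccc3c2)cc1[N+](=O)[O-])C1CCOCC1`: 269 nM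

Of the two measured compounds, compound 2 has the higher number, at 269 nM. The next member is compound 3 `CN1CCC(COc2ccc(S(=O)(=O)NC(=O)c3ccc(N4CCN(CC5=C(c6ccc(C(F)(F)F)cc6)CC(C)(C)CC5)CC4)cc3Oc3cnc4[nH]ccc4c3)cc2[N+](=O)[O-])C1`, which differs from compound 2 on the oxygen: (1-methylpyrrolidin-3-yl)methyl in place of 1-(oxan-4-yl)ethyl on an oxygen on an aromatic ring. Going by the values given here, only one measured step bears on this change: a 32-fold higher number from compound 1 to compound 2 (1.51 log units; beyond the scatter). That step is large and beyond the scatter. Compound 1 carries the same (1-methylpyrrolidin-3-yl)methyl, but on a nitrogen, whereas compound 3 keeps the oxygen of compound 2. The data do not separate the contribution of the oxygen from that of the rest of the group. Only part of the step from compound 1, at 8.3 nM, is therefore expected to be recovered in this assay. The expected change is towards a lower number and beyond the scatter, with an estimated step of a 7.7-fold lower number from compound 2 to compound 3 (0.89 log units; beyond the scatter). The estimate for compound 3 is 35 nM, with an expected range of 10 nM to 120 nM.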

Compound 3, half-maximal inhibitory concentration: 10 nM
Compound 3: middle estimate off by 3.5-fold (0.54 log units), on the high side, within the range that was stated.
By their numbers in this assay, from the lowest: compounds 1 and 3 (each within the scatter of the next); then compound 2.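

In this assay, the change on the oxygen on an aromatic ring gives a 27-fold lower number from compound 2 to compound 3 (1.43 log units; beyond the scatter); with that oxygen held in both compounds, the group on it accounts for a large step by itself, which the earlier step, where the linking atom changed too, could not show. The linking atom reads differently: (1-methylpyrrolidin-3-yl)methoxy in place of ((1-methylpyrrolidin-3-yl)methyl)amino on an aromatic carbon gives a 1.2-fold higher number from compound 1 to compound 3 (0.08 log units; within the scatter), so in this assay the oxygen and nitrogen links cannot be told apart for this group, and the large step from the earlier pair now sits with the group rather than the link. Nothing available explains why the group matters so much at this position.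

The swap from 1-(oxan-4-yl)ethyl to (1-methylpyrrolidin-3-yl)methyl changes the ring size, the ring hetero atom and the chain to the oxygen all at once, so the share of each stays unresolved. An oxan-4-ylmethyl or a 1-(1-methylpyrrolidin-3-yl)ethyl on the same oxygen would separate the ring from the chain, and a piperidine ring would test the ring size alone.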